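The source may report more compounds than this note shows. Statements on the series, on what has been measured and on what is new or still open speak of the compounds shown alone.

Compound 3 `Cc1ccc(S/C(=C/c2ccc(N(C)C)cc2)C(=O)c2ccc(Cl)cc2)cc1` belongs to a small set of related growth inhibitors tested in a functional assay on DU-145 cells (Homo sapiens) for inhibition, read by trypan blue exclusion, with a stated time of 96 h; a higher number here means a weaker inhibitor of growth, a lower number a stronger inhibitor of growth. Its result is not a number: compound 3 reaches only the limit of > 100000 nM, and that is all that is known of it. The two companions with numbers share the 4-chlorobenzyl group on sulfur. Compound 1 `O=C(/C(=C\c1ccc(Br)cc1)SCc1ccc(Cl)cc1)c1ccc(Cl)cc1` gives 1000 nM in this assay, and compound 2 `CSc1ccc(/C=C(/SCc2ccc(Cl)cc2)C(=O)c2ccc(Cl)cc2)cc1`, which carries methylsulfanyl in place of bromo, gives 25000 nM. That single exchange, a 25-fold higher number from compound 1 to compound 2 (1.40 log units; beyond the scatter), shows how strongly a change on the aromatic ring of the chain can move the number.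

Compound 4 `CN(C)c1ccc(/C=C(/SCc2ccc(Cl)cc2)C(=O)c2ccc(Cl)cc2)cc1` arises from compound 3 by 4-chlorobenzyl in place of 4-methylphenyl on a sulfur. For the measured compounds named here, no measured pair covers this exact change, so the two numbers for compound 1 and compound 2 only show that compounds bearing 4-chlorobenzyl on sulfur can give measurable values, while the dimethylamino group of compound 3 sits with a limit, (the limit of > 100000 nM in this assay, at which 1 of the 3 values shown sits), so the direction of the step cannot be read from a measured step.

The expectation is therefore cautious: compound 4 is estimated to come out near 60000 nM, with a range from 15000 nM to 250000 nM, which would mean an expected step of an at least 1.6-fold lower number from compound 3 to compound 4 (0.22 log units; that floor lies within the scatter) into measurable territory.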

Compound 4, concentration for 50% growth inhibition: > 100000 nM
Compound 4 was reported as a limit (the forecaster's own chance of this, stated with the estimate: 35%); middle value at least 1.6-fold (0.22 log units) away from the limit.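

In this assay compound 4 is a limit and not a number (> 100000 nM), which shows that 4-chlorobenzyl on the sulfur does not by itself bring a dimethylamino compound into measurable range. With 4-chlorobenzyl kept on the sulfur, the group on the aromatic carbon now separates three compounds: dimethylamino in place of methylsulfanyl gives one step (an at least 4.0-fold higher number from compound 2 to compound 4 (0.60 log units; beyond the scatter)), and dimethylamino in place of bromo gives a larger one (an at least 100-fold higher number from compound 1 to compound 4 (2.00 log units; beyond the scatter)). The step between compound 3 and compound 4 cannot be read, with a limit standing on both sides: the limit of > 100000 nM in this assay, at which 2 of the 4 values shown sit.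

Still open, from the compounds shown here alone, is whether exchanging 4-methylphenyl for 4-chlorobenzyl on a sulfur moves the number at all, and a pair carrying bromo on the aromatic carbon on both sides of that exchange could tell. Also open, going by these compounds, is how a primary amine, a hydroxyl group or a nitrile on that same aromatic carbon would compare with bromo and with dimethylamino.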